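Chloro to fluoro on the outer phenyl ring

The source may report more compounds than this note shows. Statements on the series, on what has been measured and on what is new or still open speak of the compounds shown alone.

Measured compounds:
Compound 1, `CC[C@@H](Nc1c(C#N)c(-c2ccc(-c3ccccc3OC)cc2)nc2cnccc12)C(N)=O`: 2.7
Compound 2, `CC[C@@H](Nc1c(C#N)c(-c2ccc(-c3ccccc3Cl)cc2)nc2cnccc12)C(N)=O`: 2.9

In a physicochemical assay for lipophilicity, read by HPLC, at pH 7.5 (a higher number here means a more lipophilic compound, a lower number a more polar compound), compound 2 gives 2.9, and compound 1 gives 2.7; the two numbers sit within the scatter of each other, as the step of a number 0.20 log units higher from compound 1 to compound 2 (within the scatter) shows. Compound 3, `CC[C@@H](Nc1c(C#N)c(-c2ccc(-c3ccccc3F)cc2)nc2cnccc12)C(N)=O`, is not yet measured. It differs from compound 2 by fluoro in place of chloro on an aromatic carbon. Among the compounds with values here, the only measured step, a number 0.20 log units higher from compound 1 to compound 2 (within the scatter), exchanges a different group at the same place and so bears on this change only loosely. With nothing closer to lean on, a small move downward in this assay is expected, estimated as a number 0.40 log units lower from compound 2 to compound 3 (beyond the scatter), which may well stay inside the scatter. Compound 3 is therefore expected to give about 2.5, with a likely range from 2.2 to 2.9.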

Compound 3, distribution coefficient: 2.7
The estimate for compound 3 lay 0.20 log units below the measured number, within the range that was stated.
By their numbers in this assay, from the lowest: compounds 1, 3 and 2 (each within the scatter of the next).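

In this assay the change from 2-chlorophenyl to 2-fluorophenyl gives a number 0.20 log units lower from compound 2 to compound 3 (within the scatter) and fluoro in place of methoxy gives no change at the digits printed from compound 1 to compound 3 (within the scatter) at the same place. Chloro, fluoro and methoxy have now all been read on this aromatic carbon, ortho to a large group, and no pair among the three compounds can be told apart, so this small set of exchanges leaves the reading essentially flat. Nothing available offers a reason for this flat reading.

What the compounds shown leave open is whether a group of another kind at this place, such as an amine, a carboxylic acid or a longer chain, would move the number beyond the scatter. They also leave open whether these same three groups would read alike on another carbon of the ring.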